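The compounds below may be only part of what the source reports. "The series", "measured", "known", "first", "only" and "open" are said of these compounds alone.

Measured compounds:
- Compound 1 `O=C(NO)c1ccc(CNc2nccc(-c3cccnc3)n2)cc1`: 410 nM
- Compound 2 `CC(C)(C)OC(=O)N1C(NCc2ccc(C(=O)Nc3ccccc3N)cc2)=NC(=O)C1Cc1c[nH]c2ccccc12`: 27200 nM
- Compound 3 `Nc1ccccc1NC(=O)c1ccc(CNC2=NC[C@H](c3ccccc3)S2)cc1`: 2300 nM

Of the compounds shown here, three have been measured in an assay for inhibition of histone deacetylase 8 (Homo sapiens), read by fluorescence, with stated times of 15 min and 60 min; on this read-out lower numbers stand for stronger inhibition and higher numbers for weaker inhibition. Compound 1 gives the lowest number of the three, that is, the strongest inhibition. Compound 3 gives a higher number than compound 1, and compound 2 a much higher one; both gaps lie beyond the usual scatter of this assay.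

The next compound, compound 4 `Nc1cc(C(=O)O)ccc1NC(=O)c1ccc(CNc2nccc(-c3cccnc3)n2)cc1`, is built from compound 1 by one change: 2-amino-4-carboxyphenyl in place of hydroxy on an amide-type nitrogen. The hydroxy group that leaves sits on the nitrogen of the amide, and the 2-amino-4-carboxyphenyl group takes its place there.

Going by the values given here, no step of this kind has been measured directly. Compounds 2 and 3, which also carry an amide nitrogen bearing an aminophenyl group rather than a hydroxy group, both give higher numbers in this assay than compound 1. On that basis the step from compound 1 to compound 4 is expected to raise the number, a 12-fold higher number from compound 1 to compound 4 (1.09 log units; beyond the scatter), well beyond the scatter. Compound 4 is therefore estimated at 5000 nM, with a likely range from 1500 nM to 20000 nM.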

Compound 4, half-maximal inhibitory concentration: > 20000 nM
Compound 4: a limit, no number; the forecaster's own chance of this, stated with the estimate: 15%; at least 4.0-fold (0.60 log units) between middle value and limit.
By their numbers in this assay, from the lowest: compound 1; then compound 3; then compound 2.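

In this assay compound 4 gives > 20000 nM, which is a limit of the assay and not a number. With the rest of the core held the same, 2-amino-4-carboxyphenyl in place of hydroxy on the amide-type nitrogen gives an at least 48-fold higher number from compound 1 to compound 4 (1.68 log units; beyond the scatter), so this change costs a large part of the inhibition seen with hydroxy. Going by these compounds alone, compounds 2 and 3 differ from compound 1 in more than one place, so this pair is the first to isolate the group on that nitrogen.

The full size of the step remains unknown, and the compounds shown cannot tell whether the ring, its amino group or its carboxylic acid accounts for the loss. They also leave open how a plain phenyl ring or a methoxy group on that nitrogen would read on this core.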